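The source may report more compounds than this note shows. Statements on the series, on what has been measured and on what is new or still open speak of the compounds shown alone.

Measured so far:
compound 1 `CCCNc1nc(NCc2ccc(NC(=O)c3ccc(F)cc3)cc2)c2ccccc2n1` — 1700 nM
compound 2 `CCNc1ncc(C)c(NCc2ccc(NC(=O)c3ccc(F)cc3)cc2)n1` — > 20000 nM

For the measured compounds named here, in a functional assay on HCT-116 cells (Homo sapiens) for inhibition, read by luminescence and resazurin assay, with a stated time of 3 days (on this read-out higher numbers stand for weaker inhibition and lower numbers for stronger inhibition), compound 1 gives 1700 nM, the only numerical value so far. Compound 2 reaches only > 20000 nM, which is a limit of the assay rather than a number, as recorded in the limit of > 20000 nM in this assay, at which 1 of the 2 values shown sits. Going by the values given here, no pair of measured compounds differs in a single place, so no measured step is available to anchor the next change.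

Compound 3 `CNc1nc(NCc2ccc(NC(=O)c3ccc(F)cc3)cc2)c2ccccc2n1` differs from compound 1 by hydrogen in place of ethyl on a saturated chain carbon bound to a nitrogen on an aromatic ring; cut one bond further out, propylamino becomes methylamino. The shared core is otherwise untouched. For such a shortening, a small step is expected, most likely a slight weakening or none beyond the scatter. Compound 3 is therefore estimated at 3000 nM, with a range from 1000 nM to 10000 nM. The step of a 1.8-fold higher number from compound 1 to compound 3 (0.25 log units; within the scatter) is the expected outcome of the change.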

Compound 3, half-maximal inhibitory concentration: 1600 nM
Compound 3: middle estimate off by 1.9-fold (0.27 log units), on the high side; low and high end bracket the measured number.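

In this assay, for the compounds shown here, going from propylamino to methylamino gives a 1.1-fold lower number from compound 1 to compound 3 (0.03 log units; within the scatter) and supplies the first single-place comparison. The two chain lengths cannot be told apart on this read-out. On the saturated chain carbon bound to a nitrogen on an aromatic ring, ethyl can therefore give way to hydrogen with no readable change, and nothing at hand gives a cause for this flat step.

Open, from the compounds shown here alone, is whether the same flat response extends to a longer chain such as butylamino, to a branched group such as isopropylamino, or to a plain unsubstituted amine in place of methylamino. Also open, going by these compounds, is whether a hydroxyl or a carboxylic acid at the end of the chain would leave the number in the same range.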